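Fluorine Position on the Ring Bound to Nitrogen

The source may hold more compounds than are shown below. What is called first, only, known or untested is meant among the compounds shown, and "the series" means these compounds.

Three compounds have been measured in a functional assay on SGC-7901 cells (Homo sapiens) for antiproliferative activity, read by MTT assay, with a stated time of 24 h; a lower number here means a stronger inhibitor, a higher number a weaker inhibitor:
Compound 1 `Cc1ccccc1-n1cc(-c2ccccc2NS(=O)(=O)c2c[nH]c(=O)[nH]c2=O)nn1` gives 9570 nM.
Compound 2 `Cc1ccc(-n2cc(-c3ccccc3NS(=O)(=O)c3c[nH]c(=O)[nH]c3=O)nn2)cc1` gives 6390 nM.
Compound 3 `O=c1[nH]cc(S(=O)(=O)Nc2ccccc2-c2cn(-c3ccccc3F)nn2)c(=O)[nH]1` gives 10800 nM.

Compound 3 carries the highest of the three numbers, but all three sit close together: the gap a 1.1-fold higher number from compound 1 to compound 3 (0.05 log units; within the scatter) and the gap a 1.7-fold higher number from compound 2 to compound 3 (0.23 log units; within the scatter) are both within the scatter, so no order among them can be claimed.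

Compound 4 `O=c1[nH]cc(S(=O)(=O)Nc2ccccc2-c2cn(-c3ccc(F)cc3)nn2)c(=O)[nH]1` is now the question. It differs from compound 3 only in where the fluorine sits: 4-fluorophenyl in place of 2-fluorophenyl on an aromatic nitrogen. The measured step that matches this most closely is the one in which the methyl moved in the same way, a 1.5-fold lower number from compound 1 to compound 2 (0.18 log units; within the scatter), which stayed within the scatter. The exchange of methyl for fluoro at the first position, a 1.1-fold higher number from compound 1 to compound 3 (0.05 log units; within the scatter), was also within the scatter. Nothing in these three compounds points to a shift beyond the scatter when the fluorine is moved.

Compound 4 is therefore expected to give a number close to that of compound 3, perhaps slightly lower, with the step of a 1.4-fold lower number from compound 3 to compound 4 (0.13 log units; within the scatter) expected to stay within the scatter. The estimate for compound 4 in this assay is 8000 nM, with a range from 4000 nM to 16000 nM.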

Compound 4, half-maximal inhibitory concentration: > 20000 nM
Compound 4 was reported as a limit (the forecaster's own chance of this, stated with the estimate: 5%); at least 2.5-fold (0.39 log units) between middle value and limit.
By their numbers in this assay, from the lowest: compounds 2, 1 and 3 (each within the scatter of the next). At a limit, above all of these: compound 4.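

In this assay compound 4 stands at a limit and not at a number, the only one of the set to do so: the limit of > 20000 nM in this assay, at which 1 of the 4 values shown sits. Among the compounds shown here, two steps now pass the scatter, an at least 3.1-fold higher number from compound 2 to compound 4 (0.49 log units; beyond the scatter) and an at least 2.0-fold higher number from compound 1 to compound 4 (0.32 log units; beyond the scatter), something no step among the earlier compounds did, while the move of the fluorine alone gives an at least 1.8-fold higher number from compound 3 to compound 4 (0.26 log units; that floor lies within the scatter), so that step by itself does not yet establish a real difference between 2-fluorophenyl and 4-fluorophenyl. Fluoro in place of methyl on an aromatic carbon also turns out not to be an exchange of one fixed size, as it differs between the two cores that carry it: the same change on two cores in this assay, a 1.1-fold higher number (0.05 log units; within the scatter) from compound 1 to compound 3 and an at least 3.1-fold higher number (0.49 log units; beyond the scatter) from compound 2 to compound 4, at least 2.7-fold (0.44 log units) apart, beyond the scatter of two such steps.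

Going by these compounds, how far compound 4 really lies from the other compounds stays open, and with it whether moving the fluorine alone counts for more than the scatter. Also open, on these data alone, is what a methoxy group, an amine or a carboxylic acid would give in place of the fluorine of 4-fluorophenyl, and whether any of these would bring the number back towards that of compound 2.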